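A few compounds are considered here, and "the series" means these few. Any claim that something is new, unique, unknown or untested is made for them only; others in the source may bear on it.

Measured so far:
Compound 1 `CCOC(=O)c1ccc(-c2nc(-c3ccc4c(c3)C(C)(C)CCC4(C)C)c(C)s2)cc1` — 12.1 nM
Compound 2 `CCOCCOc1nc(-c2ccc(C(=O)O)cc2)sc1C` — 56.7 nM

In an assay on isolated protein with retinoic acid receptor beta (Homo sapiens) as the target, read by TR-FRET, with a stated time of 4 h (on this read-out higher numbers stand for an effect only at larger amounts of compound and lower numbers for an effect already at smaller amounts), compound 1 gives 12.1 nM and stands at the lowest of the two numbers; the nearest, compound 2, gives 56.7 nM, a gap beyond the scatter. Compounds 1 and 2 differ in more than one place, so their values show only that both lie in the same general range.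

Compound 3 `Cc1sc(-c2ccc(C(=O)O)cc2)nc1-c1ccc2c(c1)C(C)(C)CCC2(C)C` is not yet measured. It differs from compound 1 by hydrogen in place of ethyl on an oxygen next to a carbonyl group; cut one bond further out, ethoxycarbonyl to carboxy. For the measured compounds named here, no measured pair covers this single change. Going by the values given here, a carboxy group is already present in compound 2, which gives 56.7 nM in this assay, yet that compound differs elsewhere too, so it fixes no step. The expectation for compound 3 is a modest step downward, a 2.4-fold lower number from compound 1 to compound 3 (0.38 log units; beyond the scatter), at or just beyond the scatter. Compound 3 is estimated at 5 nM, with a range from 1.2 nM to 25 nM.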

Compound 3, half-maximal effective concentration: 11 nM
For compound 3 the middle estimate is 2.2-fold (0.34 log units) below the measured one, within the range that was stated.
By their numbers in this assay, from the lowest: compounds 3 and 1 (each within the scatter of the next); then compound 2.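

Notes on the oxygen next to the carbonyl group: in this assay, exchanging ethyl for hydrogen gives a 1.1-fold lower number from compound 1 to compound 3 (0.04 log units; within the scatter), the first single-change comparison in the series. On the core of compound 1, ethoxycarbonyl and carboxy therefore read alike, so this assay does not separate the ethyl group from hydrogen at this place. No measurement at hand explains this agreement.

On these data alone, it remains open whether the same agreement would hold for a longer chain on this oxygen, such as butyl, or for an amide nitrogen in place of the oxygen. For the compounds shown here, no single-change step yet links compound 2 to compound 1 or compound 3, so the parts of the core that set compound 2 apart remain unresolved.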